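Aryloxy variation on the acetal substituent

The source may report more compounds than this note shows. Statements on the series, on what has been measured and on what is new or still open speak of the compounds shown alone.

Compound 3 `CC(C)(Oc1ccccc1)C1OCC(C/C=C\CCC(=O)O)C(c2cccnc2)O1` stands second highest of the three numbers in an assay for inhibition of Thromboxane-A synthase (Homo sapiens), using microsomes (a higher number here means a weaker inhibitor, a lower number a stronger inhibitor), where compound 3 gives 52 nM; compound 2 `O=C(O)CC/C=C\CC1COC(c2cccc3ccccc23)OC1c1cccnc1` gives 40 nM and compound 1 `O=C(O)CC/C=C\CC1COC(c2ccco2)OC1c1cccnc1` gives 164 nM. The steps of a 4.1-fold lower number from compound 1 to compound 2 (0.61 log units; beyond the scatter) and a 3.2-fold lower number from compound 1 to compound 3 (0.50 log units; beyond the scatter) are modest, and the step of a 1.3-fold higher number from compound 2 to compound 3 (0.11 log units; within the scatter) is within the scatter. Compound 4 `COc1ccc(OC(C)(C)C2OCC(C/C=C\CCC(=O)O)C(c3cccnc3)O2)c([N+](=O)[O-])c1` differs from compound 3 by 4-methoxy-2-nitrophenyl in place of phenyl on an oxygen on a saturated carbon. Among the compounds with values here, no measured step alters the group on this oxygen, so none bears on it directly; the measured steps show only that exchanges of the whole substituent on the saturated ring carbon shift the number modestly at most, with compound 2 and compound 3 near level. In this assay a step no larger than the scatter is therefore expected from compound 3 to compound 4, a 1.2-fold lower number from compound 3 to compound 4 (0.06 log units; within the scatter). Compound 4 is estimated at 45 nM, with a range of 15 nM to 140 nM.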

Compound 4, half-maximal inhibitory concentration: 37 nM
Compound 4: the middle estimate sits 1.2-fold (0.09 log units) above what was measured; low and high end bracket the measured number.
By their numbers in this assay, from the lowest: compounds 4, 2 and 3 (each within the scatter of the next); then compound 1.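

In this assay, within the data shown here, the change at this oxygen, 4-methoxy-2-nitrophenyl in place of phenyl, gives a 1.4-fold lower number from compound 3 to compound 4 (0.15 log units; within the scatter) and is the first measured change to this group. The phenyl therefore takes the added methoxy and nitro groups together with no shift beyond the scatter. Nothing available explains this tolerance.

On these data alone, the methoxy and nitro groups appear only together, so what each contributes alone stays open. Also open, as far as these compounds go, is how an amine or a carboxylic acid on this phenyl would read in this assay.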